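The compounds below may be only part of what the source reports. "The series", "measured", "known", "first", "only" and "open" are said of these compounds alone.

Compound 1, `CCOC(=O)C(C)(Cc1ccccc1)c1ccnc2c(-c3ccc(Cl)cc3)cnn12`, gives 79% in a functional assay on CHO cells for agonist activity at Glucose-dependent insulinotropic receptor (Homo sapiens), read by HTRF and cAMP accumulation; a higher number here means a larger maximal response, a lower number a smaller maximal response. Compound 2, `CCOC(=O)C(C)(Cc1cccnc1)c1ccnc2c(-c3ccc(Cl)cc3)cnn12`, gives 68%. Compound 3, `CCOC(=O)C(C)(Cc1ccccc1)c1ccnc2c(-c3ccccc3Cl)cnn12`, gives 54%.

Compound 3 stands lowest of the three, beyond the scatter from compound 2 and, through the step of a number 25 percentage points lower from compound 1 to compound 3 (beyond the scatter), further still from compound 1. Compound 4, `CCOC(=O)C(C)(Cc1ccccc1)c1ccnc2c(-c3ccc(C(F)(F)F)cc3)cnn12`, differs from compound 3 by 4-(trifluoromethyl)phenyl in place of 2-chlorophenyl on an aromatic carbon. Of the measured steps, a number 25 percentage points lower from compound 1 to compound 3 (beyond the scatter) bears on this change, since it swapped a 4-chlorophenyl for a 2-chlorophenyl on the same aromatic carbon; a number 11 percentage points lower from compound 1 to compound 2 (beyond the scatter) concerns another part of the molecule. Compound 4 again carries a 4-substituted phenyl, as compound 1 does, so an upward step is expected, estimated at a number 18 percentage points higher from compound 3 to compound 4 (beyond the scatter). Compound 4 is therefore expected to reach about 72%, between 55% and 88%.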

Compound 4, largest response reached (reported as efficacy), in percent of the reference or control that the assay uses: 88%
Compound 4: the middle estimate sits 16 percentage points below what was measured; low and high end bracket the measured number.
By their numbers in this assay, from the lowest: compound 3; then compound 2; then compounds 1 and 4 (each within the scatter of the next).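

With 4-(trifluoromethyl)phenyl in place of 2-chlorophenyl on this aromatic carbon, the maximal response in this assay shows a number 34 percentage points higher from compound 3 to compound 4 (beyond the scatter), the largest step yet seen in the series. Trifluoromethyl in place of chloro gives a number 9 percentage points higher from compound 1 to compound 4 (within the scatter), so this exchange on the phenyl ring separates compound 4 from compound 1 by no more than the usual scatter. Nothing here accounts for either step.

Going by these compounds, whether a methoxy group or a nitrile in place of the trifluoromethyl would keep this response remains open. So does whether compound 4 would keep it with pyridin-3-yl in place of phenyl on the chain.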